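The source may report more compounds than this note shows. Statements on the series, on what has been measured and on what is new or still open speak of the compounds shown alone.

Working notes on the series.

Compound 1 `O=C(Nc1ccc(F)cc1)Nc1ccc2c(c1)COC2=O` carries a 4-fluorophenyl group on one core, and compound 2 `O=C(Nc1ccc(Cl)cc1)Nc1ccc2c(c1)COC2=O` is its partner with chloro in place of fluoro on an aromatic carbon. In a functional assay on cells (T-cell, Mus musculus) for inhibition (on this read-out higher numbers stand for weaker inhibition and lower numbers for stronger inhibition), compound 1 gives 4190 nM, and compound 2 gives 2450 nM. The step of a 1.7-fold lower number from compound 1 to compound 2 (0.23 log units; within the scatter) is therefore small and, as recorded, within the scatter of repeated measurements; on these two values alone no order between compound 1 and compound 2 can be stated.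

Compound 3 `O=C(Nc1ccc(F)cc1)C(=O)Nc1ccc2c(c1)COC2=O` is built on a second core. The difference between the two cores is not broken down here. In this assay compound 3 gives 570 nM, the lowest of the three numbers, and its gaps to compound 2 and to compound 1 are both beyond the scatter.

Compound 4 `O=C(Nc1ccc(Cl)cc1)C(=O)Nc1ccc2c(c1)COC2=O` has not yet been measured. It stands to compound 3 as compound 2 stands to compound 1, with chloro in place of fluoro on an aromatic carbon. The place of the change is described in the same words in both pairs, so this is the same change made on the second core. Going by the values given here, the only measured instance of it, from compound 1 to compound 2, moved the number within the scatter, so in this assay the step from compound 3 to compound 4 is expected to be about as small, a 1.4-fold lower number from compound 3 to compound 4 (0.15 log units; within the scatter), resting on a 1.7-fold lower number from compound 1 to compound 2 (0.23 log units; within the scatter) and on the value of compound 3, 570 nM. Compound 4 is accordingly expected to give about 400 nM, in the range from 200 nM to 800 nM.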

Compound 4, half-maximal inhibitory concentration: 2240 nM
For compound 4 the middle estimate is 5.6-fold (0.75 log units) below the measured one; measured number above the stated range.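

On the second core, chloro in place of fluoro gives a 3.9-fold higher number from compound 3 to compound 4 (0.59 log units; beyond the scatter) in this assay, whereas on the first core the same change stayed within the scatter, so the two cores do not share one step for this change: the same change on two cores in this assay, a 1.7-fold lower number (0.23 log units; within the scatter) from compound 1 to compound 2 and a 3.9-fold higher number (0.59 log units; beyond the scatter) from compound 3 to compound 4, 6.7-fold (0.83 log units) apart, beyond the scatter of two such steps

For this series, then, a step read on one core cannot simply be carried to the other, and the small step on the first core gave no warning of the larger step on the second. This does not show why the two cores part, nor that the change behaves differently on cores beyond these two, since the comparison rests on a single pair of compounds for each core and on one read-out.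

The compounds shown hold only fluoro and chloro at this place, so it remains open whether the two cores would also part for a bromo, methyl or methoxy group there. A nitrile at the same place on both cores would help show whether the gap is particular to the fluoro and chloro pair or extends to other groups.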